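From compound 3 to compound 4: phenyl gives way to isopropyl

The compounds below may be only part of what the source reports. "The series", "measured", "known", "first", "only" and "open" are said of these compounds alone.

Compound 1 `COc1cc2nc(C3CCC3)nc(N3CCN(c4ccccc4)CC3)c2cc1OC` is the parent of this set. In an in vitro assay on U2OS cells for agonist activity at neurotensin receptor type 2 (Homo sapiens), read by reporter gene assay and beta-arrestin recruitment (on this read-out higher numbers stand for an effect only at larger amounts of compound and lower numbers for an effect already at smaller amounts), compound 1 gives only a limit, > 80000 nM. Compound 2 `COc1cc2nc(C3CCC3)nc(N3CCN(c4ccccc4Cl)CC3)c2cc1OC` carries chloro in place of hydrogen on an aromatic carbon; in this assay compound 2 also gives only a limit, > 80000 nM. The step that the two limits leave unreadable from compound 1 to compound 2 is therefore of unreadable size. Compound 3 `COc1cc2nc(Cc3ccccc3)nc(N3CCN(c4ccccc4OC)CC3)c2cc1OC` in this assay likewise gives only a limit, > 80000 nM. Compound 3 thus stands where every value shown stands, at the limit of > 80000 nM in this assay, at which 3 of the 3 values shown sit, and no numbered value exists in the set. Compound 4 `COc1cc2nc(CC(C)C)nc(N3CCN(c4ccccc4OC)CC3)c2cc1OC` differs from compound 3 by isopropyl in place of phenyl on a saturated chain carbon bound to an aromatic carbon. For the measured compounds named here, no measured step bears on this change; the one step recorded, a step that the two limits leave unreadable from compound 1 to compound 2, touches another part of the molecule and is itself unreadable. Nothing in the set suggests that compound 4 would enter the measurable range, so compound 4 is expected to show a step that the limit leaves unreadable from compound 3 to compound 4 not beyond the scatter, most likely again only a limit. The estimate for compound 4 in this assay is 100000 nM, with a range from 30000 nM to 300000 nM.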

Compound 4, half-maximal effective concentration: > 80000 nM
Compound 4: no number, only a limit; the forecaster's own chance of this, stated with the estimate: 85%; the middle value is on the limit's open side.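

Compound 3 and compound 4 both give only a limit in this assay, so no step can be read between them and the change from phenyl to isopropyl has no readable size: the limit of > 80000 nM in this assay, at which 4 of the 4 values shown sit.

The compounds shown leave open whether any change to the shared core gives a numbered value in this assay at all.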